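Two Aryl Piperidine Amides and a Thiophene Analogue

The compounds below may be only part of what the source reports. "The series", "measured", "known", "first", "only" and "open" are said of these compounds alone.

Compound 1 `O=C(Nc1ccc(Cl)cc1)C1CCCN(C(=O)c2cccc(-c3ccco3)c2)C1` and compound 2 `N#Cc1cccc(C(=O)N2CCCC(C(=O)Nc3ccc(Cl)cc3)C2)c1` share a core in which a piperidine amide carries a chloroanilide on one side and an aroyl group on the other. In an ADME assay on PC-3 cells (Homo sapiens) for cytotoxicity, read by WST assay, tested at 100 uM (a lower number here means less inhibition, a higher number more inhibition at the concentration tested (going by the name of the read-out)), compound 1 gives 0%, and compound 2 gives 0%. The step of no change at the digits printed from compound 1 to compound 2 (within the scatter) is flat, and compound 2 stands level with compound 1 on these numbers; both sit at the floor of this assay.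

Compound 3 `O=C(Nc1ccc(Cl)cc1)C1CCCN(C(=O)c2cccc(-c3cccs3)c2)C1` has not yet been measured in this assay. It differs from compound 2 in one place, (thiophen-2-yl in place of cyano on an aromatic carbon). Going by the values given here, the only measured step that bears on this change is no change at the digits printed from compound 1 to compound 2 (within the scatter), in which a five-membered aromatic ring at this position gave the same reading as the cyano group. Since neither the furan-2-yl of compound 1 nor the cyano of compound 2 moved the reading off the floor, no step beyond the scatter is expected for no change at the digits printed from compound 2 to compound 3 (within the scatter). Compound 3 is therefore estimated at 0% in this assay, within a range from -10% to 12%.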

Compound 3, a percentage reported as inhibition, at one concentration (the size of the read-out at that concentration, not a potency): 4%
The estimate for compound 3 lay 4 percentage points below the measured number; the range from low to high includes it.
By their numbers in this assay, from the lowest: compounds 1, 2 and 3 (each within the scatter of the next).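

In this assay the new readings give a number 4 percentage points higher from compound 2 to compound 3 (within the scatter), and they also give a number 4 percentage points higher from compound 1 to compound 3 (within the scatter). This extends the flat picture at this place, on a six-membered aromatic ring of carbon only and meta to a large group: thiophen-2-yl, with its 5 heavy atoms including 1 sulfur, cannot be told apart from cyano, with 2 heavy atoms and a triple bond, or from furan-2-yl, the other five-membered aromatic ring. Across these three compounds, neither the swap of one five-membered aromatic ring for another nor the exchange of cyano for such a ring produces a step beyond the scatter, and no measurement is available that would account for these readings.

The compounds shown all keep the rest of the shared core unchanged, so they leave open whether an amine, a carboxylic acid or a longer chain at this place would give a reading that stands apart from these three. They also leave open whether replacing the chlorine on the anilide with a methoxy group would do so.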